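Compound 4: piperazin-1-yl for 3-hydroxypiperidin-1-yl

The source may report more compounds than this note shows. Statements on the series, on what has been measured and on what is new or still open speak of the compounds shown alone.

Compound 1 `CC(C)c1cc(-n2cc(-c3ccc(CN4CCN(c5ccccc5)CC4)cc3)nn2)c(O)cc1O`: > 1000 nM
Compound 2 `CC(C)c1cc(-n2nncc2-c2ccc(CN3CCCC(O)C3)cc2)c(O)cc1O`: 45 nM
Compound 3 `CCNC(=O)c1nnn(-c2cc(C(C)C)c(O)cc2O)c1-c1ccc(CN2CCC[C@@H](O)C2)cc1`: 52 nM

In a functional assay on NCI-H460 cells (Homo sapiens) for inhibition, read by sulforhodamine B assay, with a stated time of 72 h (a lower number here means a stronger inhibitor, a higher number a weaker inhibitor), compound 3 gives 52 nM, which lies within the scatter of compound 2 at 45 nM. Compound 1 reports only a limit of the assay, > 1000 nM. Compound 4 `CCNC(=O)c1nnn(-c2cc(C(C)C)c(O)cc2O)c1-c1ccc(CN2CCNCC2)cc1` keeps the core of compound 3 and carries piperazin-1-yl in place of 3-hydroxypiperidin-1-yl on a saturated chain carbon bound to an aromatic carbon. For the measured compounds named here, no measured pair of compounds shows this change, and no step beyond the scatter is expected in this assay. The expected step is a 1.3-fold higher number from compound 3 to compound 4 (0.13 log units; within the scatter), an estimate that stays within the scatter. For compound 4 the estimated value is 70 nM, with an expected range of 25 nM to 200 nM.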

Compound 4, half-maximal inhibitory concentration: 250 nM
Compound 4: the middle estimate sits 3.6-fold (0.55 log units) below what was measured; the measured number lies above the stated range.
By their numbers in this assay, from the lowest: compounds 2 and 3 (each within the scatter of the next); then compound 4. At a limit, above all of these: compound 1.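

Compounds 2 and 3 both carry 3-hydroxypiperidin-1-yl, so only this result shows that the ring on the saturated chain carbon bound to an aromatic carbon matters in this assay: piperazin-1-yl in its place gives a 4.8-fold higher number from compound 3 to compound 4 (0.68 log units; beyond the scatter). The step comes although both groups count the same hydrogen-bond donors and acceptors. Nothing measured here accounts for it. The compounds shown leave open whether the step follows the loss of the hydroxyl oxygen and defined stereocentre or the gain of the second ring nitrogen. Unsubstituted piperidin-1-yl and morpholin-4-yl at this place would separate these.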